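A few compounds are considered here, and "the series" means these few. Any claim that something is new, unique, unknown or untested is made for them only; others in the source may bear on it.

Working notes on the series in an ADME assay on THP-1 cells (Homo sapiens) for cytotoxicity, read by trypan blue exclusion, with a stated time of 24 h; on this read-out higher numbers stand for weaker inhibition and lower numbers for stronger inhibition. Of the compounds shown here, three have values so far. Compound 1 (`CN(C)c1ccc([Se]C#N)cc1`) gives 44700 nM, compound 2 (`N#C[Se]Cc1cccc([N+](=O)[O-])c1`) gives 9320 nM, and compound 3 (`N#C[Se]Cc1ccc(Br)cc1`) gives 28900 nM. Compound 3 therefore lies within the scatter of compound 1, while compound 2 has a lower number, and that gap from compound 3 lies beyond the scatter.

Compound 4 (`N#C[Se]Cc1ccc(C#N)cc1`) is the next to be read. It has cyano in place of bromo on an aromatic carbon, para to a group of 4 heavy atoms: cyano in place of bromo on an aromatic carbon. For the measured compounds named here, no measured pair differs in one place, so this change has no direct precedent. Going by the values given here, the only guide is the narrow span of the three values, which runs down to compound 2 at 9320 nM. The expected 1.6-fold lower number from compound 3 to compound 4 (0.21 log units; within the scatter) is small, toward a lower number, and is not expected to pass beyond the scatter. For compound 4 the estimated value is 18000 nM, with an expected range of 7000 nM to 45000 nM.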

Compound 4, half-maximal inhibitory concentration: 7970 nM
Estimate against measurement, compound 4: 2.3-fold (0.35 log units) above, within the range that was stated.
By their numbers in this assay, from the lowest: compounds 4 and 2 (each within the scatter of the next); then compounds 3 and 1 (each within the scatter of the next).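

In this assay, for the compounds shown here, the series now has its first comparison of compounds that differ in one place: cyano in place of bromo on an aromatic carbon gives a 3.6-fold lower number from compound 3 to compound 4 (0.56 log units; beyond the scatter), the only step read so far. The position para to a group of 4 heavy atoms thus responds to a change of substituent, and this change goes toward stronger inhibition. No measurement on either group bears on the step, and its cause remains unknown.

The compounds shown leave open whether other groups at this place, such as an amine, a carboxylic acid or a methoxy group, would move the number further, or in the opposite direction. Also open, going by these compounds, is whether the same change would give a step of similar size on the core of compound 1.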